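This account rests on a few compounds, and the source may have more. Where it says the series, first, only, none or still open, it means among the compounds named here.

Compound 1, `COc1cc2c(Oc3ccc(NC(=O)N/N=C/c4ccc(OC(F)(F)F)cc4)cc3F)ccnc2cc1OCCCN1CCCCC1`: 510 nM in a functional assay on HT-29 cells (Homo sapiens) for cytotoxicity, read by MTT assay, with a stated time of 72 h; on this read-out lower numbers stand for stronger inhibition and higher numbers for weaker inhibition.
Compound 2, `COc1cc2c(Oc3ccc(NC(=O)N/N=C/c4ccncc4)cc3F)ccnc2cc1OCCCN1CCCCC1`: 940 nM in this assay.

Among the measured compounds shown here, on the two numbers in hand, compound 2 gives the higher one, with compound 1 as its only neighbour; the gap between them, a 1.8-fold higher number from compound 1 to compound 2 (0.27 log units; within the scatter), lies within the scatter, so neither compound can be called the more potent of the pair. Compound 3, `COc1cc2c(Oc3ccc(NC(=O)N/N=C/c4cc5ccccc5[nH]4)cc3F)ccnc2cc1OCCCN1CCCCC1`, differs from compound 2 in one place: 1H-indol-2-yl in place of pyridin-4-yl on a carbon with a double bond to nitrogen. For the measured compounds named here, the only measured step that bears on this position is a 1.8-fold higher number from compound 1 to compound 2 (0.27 log units; within the scatter), and it stayed within the scatter. That exchange swapped one six-membered aromatic group for another, whereas the present change brings in a larger group with a hydrogen-bond donor and no hydrogen-bond acceptor in place of one with a single acceptor, so the earlier step is only a loose guide. The data give no reason to expect a movement in this assay that clears the scatter in either direction. Compound 3 is therefore expected to give 600 nM, between 200 nM and 1800 nM, an estimated step of a 1.6-fold lower number from compound 2 to compound 3 (0.19 log units; within the scatter).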

Compound 3, half-maximal inhibitory concentration: 820 nM
For compound 3 the middle estimate is 1.4-fold (0.14 log units) below the measured one; the measured number falls inside the stated range.
By their numbers in this assay, from the lowest: compounds 1, 3 and 2 (each within the scatter of the next).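

Among the compounds shown here, the step of a 1.1-fold lower number from compound 2 to compound 3 (0.06 log units; within the scatter) shows that in this assay, on the carbon with a double bond to nitrogen, 1H-indol-2-yl can stand in place of pyridin-4-yl without a movement that clears the scatter, although the entering group brings a five-membered aromatic ring and a hydrogen-bond donor that the earlier compounds lacked at this place. The step of a 1.6-fold higher number from compound 1 to compound 3 (0.21 log units; within the scatter) gives the same reading against 4-(trifluoromethoxy)phenyl, so the three groups, which the earlier pair could compare only as six-membered aromatic groups, now all lie within the scatter of one another. Nothing measured here offers an explanation for this reading.

On these data alone, all three compounds carry an aromatic group on this carbon, so it remains open whether a group of another kind there, such as a carboxylic acid, an open-chain amine or a plain methyl, would give a number that clears the scatter. As far as these compounds go, it also remains open whether the three groups would read alike on cells other than those of this assay, or with the rest of the shared core changed.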